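The source may report more compounds than this note shows. Statements on the series, on what has been measured and on what is new or still open speak of the compounds shown alone.

The three measured compounds, all sharing one core and differing only in the group at the end of the side chain:

- compound 1, `CS(=O)(=O)CC[C@@H](CN1CCc2cc(F)ccc21)NC(=O)[C@H](CC1CCCCC1)Nc1nc2ccc(Cl)cc2o1`, which in an assay on isolated protein for inhibition of cathepsin S (Homo sapiens) (a higher number here means a weaker inhibitor, a lower number a stronger inhibitor), gives 21 nM
- compound 2, `O=C(O)C[C@@H](CN1CCc2cc(F)ccc21)NC(=O)[C@H](CC1CCCCC1)Nc1nc2ccc(Cl)cc2o1`, which in this assay gives 27 nM
- compound 3, `CCOC(=O)C[C@@H](CN1CCc2cc(F)ccc21)NC(=O)[C@H](CC1CCCCC1)Nc1nc2ccc(Cl)cc2o1`, which in this assay gives 71 nM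

Compound 3 has the highest number of the three. The step from compound 1 to compound 2 is a 1.3-fold higher number from compound 1 to compound 2 (0.11 log units; within the scatter), whereas a 3.4-fold higher number from compound 1 to compound 3 (0.53 log units; beyond the scatter) and a 2.6-fold higher number from compound 2 to compound 3 (0.42 log units; beyond the scatter) both reach beyond the scatter, so compound 3 is the weakest of the measured set.

Compound 4, `CC(C)(C)OC(=O)C[C@@H](CN1CCc2cc(F)ccc21)NC(=O)[C@H](CC1CCCCC1)Nc1nc2ccc(Cl)cc2o1`, differs from compound 3 by tert-butyl in place of ethyl on an oxygen next to a carbonyl group. Among the measured compounds shown here, the one measured step that bears on this place is the step from compound 2 to compound 3, where adding ethyl to the same oxygen gave a 2.6-fold higher number from compound 2 to compound 3 (0.42 log units; beyond the scatter). For the measured compounds named here, no measured step compares two different alkyl groups on that oxygen, so the direction of a further enlargement is uncertain. Compound 4 is expected to give a number near that of compound 3, or modestly higher, the expected step being a 1.4-fold higher number from compound 3 to compound 4 (0.15 log units; within the scatter). The estimate for compound 4 in this assay is 100 nM, ranging from 40 nM to 250 nM.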

Compound 4, inhibition constant: 730 nM
Compound 4: middle estimate off by 7.3-fold (0.86 log units), on the low side; measured number outside the range, above it.
By their numbers in this assay, from the lowest: compounds 1 and 2 (each within the scatter of the next); then compound 3; then compound 4.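

In this assay, among the compounds shown here, the group on the oxygen next to a carbonyl group turns out to matter far more than the earlier compounds showed: tert-butyl in place of ethyl, a change from 2 carbons to 4, gives a 10-fold higher number from compound 3 to compound 4 (1.01 log units; beyond the scatter), a much larger step than a 2.6-fold higher number from compound 2 to compound 3 (0.42 log units; beyond the scatter). The ester with tert-butyl also falls well behind the two strongest side chains, with a 27-fold higher number from compound 2 to compound 4 (1.43 log units; beyond the scatter) and a 35-fold higher number from compound 1 to compound 4 (1.54 log units; beyond the scatter), so this end of the side chain does not accept every ester alike. Nothing in the data shown explains this sharp rise in the number.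

Going by these compounds, with only ethyl and tert-butyl on that oxygen, it remains open whether an isopropyl or a methyl ester would sit between them or follow a different trend. It is also unknown how an amide in place of the ester would compare with the carboxylic acid of compound 2.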